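A few compounds are considered here, and "the series" means these few. Any claim that something is new, unique, unknown or untested is made for them only; others in the source may bear on it.

Measured compounds in a functional assay on HT-29 cells (Homo sapiens) for antiproliferative activity, with a stated time of 48 h; on this read-out lower numbers stand for stronger inhibition and higher numbers for weaker inhibition:
compound 1 `O=C(CCCCl)Nc1ccc(I)cc1`, > 100000 nM (a limit of the assay)
compound 2 `CC(C)(C)c1ccc(CNC(=O)CCCCl)cc1`, 72000 nM
compound 3 `C=CC(=O)Nc1ccc(I)cc1`, 15000 nM

The value of compound 1 in this assay is a limit, not a number (the limit of > 100000 nM in this assay, at which 1 of the 3 values shown sits). The change from compound 1 to compound 3 is vinyl in place of 3-chloropropyl on a carbonyl carbon and gives an at least 6.6-fold lower number from compound 1 to compound 3 (0.82 log units; beyond the scatter). Compound 2 differs from compound 1 in more than one place, and the difference between the two cores is not broken down here; compound 2 and compound 3 differ by the amount stated above.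

Compound 4 `C=CC(=O)NCc1ccc(C(C)(C)C)cc1` is not yet measured. It differs from compound 2 by vinyl in place of 3-chloropropyl on a carbonyl carbon, the same kind of change as from compound 1 to compound 3. The step from compound 2 to compound 4 in this assay is expected to be a 7.2-fold lower number from compound 2 to compound 4 (0.86 log units; beyond the scatter), resting on the step seen from compound 1 to compound 3 an at least 6.6-fold lower number from compound 1 to compound 3 (0.82 log units; beyond the scatter) and on compound 2 starting at 72000 nM. Compound 4 is therefore estimated at 10000 nM, with a range from 3000 nM to 40000 nM.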

Compound 4, half-maximal inhibitory concentration: > 100000 nM
Compound 4: no number, only a limit; the forecaster's own chance of this, stated with the estimate: 5%; middle value at least 10-fold (1.00 log units) away from the limit.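

In this assay compound 4 gives > 100000 nM, which is a limit of the assay and not a number. Vinyl in place of 3-chloropropyl on a carbonyl carbon does not carry over from the core of compound 1 to the core of compound 2, with the new step reading an at least 1.3-fold higher number from compound 2 to compound 4 (0.14 log units; that floor lies within the scatter), and the two steps differ: the same change on two cores in this assay, an at least 6.6-fold lower number (0.82 log units; beyond the scatter) from compound 1 to compound 3 and an at least 1.3-fold higher number (0.14 log units; that floor lies within the scatter) from compound 2 to compound 4, at least 9.2-fold (0.96 log units) apart, beyond the scatter of two such steps This does not show the true size of either step or why the two cores part, and these values rest partly on one shared limit: the limit of > 100000 nM in this assay, at which 2 of the 4 values shown sit.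

The compounds shown leave open whether the gain on the core of compound 1 is specific to vinyl. An ethyl group or a longer chain on the same carbonyl carbon, on both cores, would bear on this.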